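This account rests on a few compounds, and the source may have more. Where it says the series, first, only, none or still open, it means among the compounds named here.

Values measured in an ADME assay on J774.A1 cells (Mus musculus) for cytotoxicity; on this read-out lower numbers stand for higher toxicity in this test and higher numbers for lower toxicity in this test:

- Compound 1 `Fc1ccc(N2CCN(c3nc(-n4ccc5ccccc54)c4ccccc4n3)CC2)cc1`: 23.4 ug/mL
- Compound 2 `COc1cc(OC)c(-c2nc(N3CCN(C)CC3)nc3ccccc23)c(OC)c1`: > 100 ug/mL
- Compound 3 `Cn1cc(-c2nc(N3CCNCC3)nc3ccccc23)c2ccccc21`: 16 ug/mL

The entry for compound 2 is a limit of the assay and not a number. Compound 3, at 16 ug/mL, and compound 1, at 23.4 ug/mL, lie within the usual scatter of each other, so these two results cannot be told apart.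

Compound 4 `CN1CCN(c2nc(-c3cn(C)c4ccccc34)c3ccccc3n2)CC1` differs from compound 3 in one place: methyl in place of hydrogen on an amine nitrogen in a ring, turning piperazin-1-yl into 4-methylpiperazin-1-yl (methyl in place of hydrogen on an amine nitrogen in a ring). Going by the values given here, no measured pair shows this change on its own, which leaves the expectation loose. Starting from the 16 ug/mL of compound 3, a small move toward a higher number in this assay is expected, possibly no larger than the scatter. The expected change is a 1.6-fold higher number from compound 3 to compound 4 (0.19 log units; within the scatter). For compound 4 the estimated value is 25 ug/mL, with an expected range of 10 ug/mL to 70 ug/mL.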

Compound 4, half-maximal cytotoxic concentration: 1.03 ug/mL
Beside the measured number, compound 4's estimate is 24-fold (1.39 log units) above it; measured number outside the range, below it.
By their numbers in this assay, from the lowest: compound 4; then compounds 3 and 1 (each within the scatter of the next). At a limit, above all of these: compound 2.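

In this assay the change from piperazin-1-yl to 4-methylpiperazin-1-yl gives a 16-fold lower number from compound 3 to compound 4 (1.19 log units; beyond the scatter) and so shows that one added methyl on this amine nitrogen is enough to make the compound clearly more toxic to these cells. Going by these compounds alone, the earlier compounds differ from one another in more than one place, so only this pair shows the effect of this position on its own. Nothing measured here accounts for so large a step from so small a change.

Going by these compounds, it remains open whether the step belongs to methyl alone or would also appear with an ethyl group, a longer chain or an acetyl group on the same nitrogen. On these data alone, it is also open whether the step would keep its size if the other large group on the shared core were different.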